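Trifluoromethyl for chloro on the aniline of compound 3

This account rests on a few compounds, and the source may have more. Where it says the series, first, only, none or still open, it means among the compounds named here.

Compound 3 `COc1ccc(S(=O)(=O)c2nc3ccccc3nc2Nc2ccc(Cl)cc2)cc1` gives 31800 nM in a functional assay on PC-3 cells (Homo sapiens) for cytotoxicity, read by MTT assay, with a stated time of 72 h (a lower number here means a stronger inhibitor, a higher number a weaker inhibitor), the highest number among the three measured compounds. Compound 2 `COc1ccc(S(=O)(=O)c2nc3ccccc3nc2Nc2cccc(N)c2)cc1` gives 8600 nM, and compound 1 `O=S(=O)(c1ccccc1)c1nc2ccccc2nc1Nc1ccc(C(F)(F)F)cc1` gives 3550 nM. Within the data shown here, the one measured step, a 3.7-fold higher number from compound 2 to compound 3 (0.57 log units; beyond the scatter), changes the aniline substituent alone, and no measured pair isolates the present change.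

Compound 4 `COc1ccc(S(=O)(=O)c2nc3ccccc3nc2Nc2ccc(C(F)(F)F)cc2)cc1` differs from compound 3 by trifluoromethyl in place of chloro on an aromatic carbon. Compound 1 carries the same trifluoromethyl aniline on a sulfonyl phenyl without the methoxy group, so it bears on the step only indirectly; its value lies well under that of compound 3, which suggests the direction of the change. The expected step of a 2.7-fold lower number from compound 3 to compound 4 (0.42 log units; beyond the scatter) is therefore toward a lower number, of a size comparable to the aniline step already seen, though with wide uncertainty since no direct comparison exists.

Compound 4 is expected to give 12000 nM in this assay, with a range from 4000 nM to 36000 nM.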

Compound 4, half-maximal inhibitory concentration: 330 nM
For compound 4 the middle estimate is 36-fold (1.56 log units) above the measured one; measured number outside the range, below it.
By their numbers in this assay, from the lowest: compound 4; then compound 1; then compound 2; then compound 3.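

In this assay, among these compounds, the substituent on the aniline weighs far more than the earlier compounds showed: trifluoromethyl in place of chloro on an aromatic carbon, para to a large group, gives a 96-fold lower number from compound 3 to compound 4 (1.98 log units; beyond the scatter) as a large step. Changing the whole aniline group, 4-(trifluoromethyl)phenyl in place of 3-aminophenyl, gives a 26-fold lower number from compound 2 to compound 4 (1.42 log units; beyond the scatter) and is also large. The sulfonyl phenyl matters as well once the trifluoromethyl aniline is held fixed, since methoxy in place of hydrogen gives an 11-fold lower number from compound 1 to compound 4 (1.03 log units; beyond the scatter) as a further large step, and no measured property of these groups is at hand to account for any of the three.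

From the compounds shown here alone, whether a nitrile or a bromine on the aniline would match trifluoromethyl remains open. So does whether an ethoxy group or a hydroxyl could stand in for the methoxy group on the sulfonyl phenyl.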